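The source may report more compounds than this note shows. Statements on the series, on what has been measured and on what is new or still open speak of the compounds shown alone.

Measured compounds in a functional assay on MCF7 cells (Homo sapiens) for antiproliferative activity; a higher number here means a weaker inhibitor, a lower number a stronger inhibitor:
- compound 1 `CCCCn1c(Cc2c(Br)c(OC)c(OC)c(OC)c2Br)nc2c(N)ncnc21`: 30200 nM
- compound 2 `COc1cc(Cc2nc3c(N)ncnc3n2CC(C)C)cc(OC)c1OC`: 97700 nM
- compound 3 `C=CCCCn1c(Cc2cc(OC)c(OC)c(OC)c2)nc2c(N)nc(F)nc21`: 44700 nM

Compound 2 gives the highest of the three numbers. Compound 3 sits nearest to it and compound 1 furthest, and both of those gaps lie beyond the scatter, so compound 2 is the weakest inhibitor of the three as the numbers now stand. Within the data shown here, compound 1 and compound 3 each carry a different set of ring substituents and a different chain on the aromatic nitrogen, so no single-point step connects any pair of measured compounds.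

Compound 4 `CCC(C)Cn1c(Cc2cc(OC)c(OC)c(OC)c2)nc2c(N)ncnc21` is the next compound, not yet measured. It differs from compound 2 only as follows: methyl in place of hydrogen on a saturated chain carbon, three bonds along the chain from an aromatic nitrogen. Among the measured compounds shown here, nothing among the measured compounds isolates this change, so its size is not known from a direct comparison. Compound 1 and compound 3, the two with longer chains on the aromatic nitrogen, both give lower numbers than compound 2, though other parts of their structures differ as well. A small step toward a lower number in this assay is therefore expected, possibly within the scatter. The expected step of a 1.6-fold lower number from compound 2 to compound 4 (0.21 log units; within the scatter) is estimated to be modest. Compound 4 is expected to give about 60000 nM, within a range from 20000 nM to 150000 nM.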

Compound 4, half-maximal inhibitory concentration: 61700 nM
For compound 4 the middle estimate is 1.0-fold (0.01 log units) below the measured one, and the stated range covers the measured number.
By their numbers in this assay, from the lowest: compounds 1, 3, 4 and 2 (each within the scatter of the next, the first and the last beyond it).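

In this assay, among these compounds, the change from isobutyl to 2-methylbutyl gives a 1.6-fold lower number from compound 2 to compound 4 (0.20 log units; within the scatter) as the first single-point step. Methyl in place of hydrogen on this saturated chain carbon, three bonds along the chain from an aromatic nitrogen, therefore leaves compound 4 not separable from compound 2 by this read-out, so the added carbon is tolerated here but shows no clear gain. No supporting data bear on the reason for so small a step.

Open, from the compounds shown here alone, is whether a longer chain, a hydroxyl, an amine or a phenyl ring at this chain carbon would give a step beyond the scatter. The effects of the bromo and fluoro substituents in the other compounds also remain unresolved, since those compounds differ from compound 2 in more than one place.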